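The source may hold more compounds than are shown below. What is called first, only, known or untested is meant among the compounds shown, and "the series" means these compounds.

In a functional assay on PC-3 cells (Homo sapiens) for antiproliferative activity, read by MTT assay, with a stated time of 48 h (a higher number here means a weaker inhibitor of growth, a lower number a stronger inhibitor of growth), compound 1 `CCCCCCCCN(Cc1ccc(C(=O)NO)cc1)c1ncc(-c2ccc(C)cc2)s1` gives 13300 nM and compound 2 `CCCCCCN(Cc1ccc(C(=O)NO)cc1)c1ncc(-c2ccc(C)cc2)s1` gives 5270 nM, so compound 2 has the lower number of the two. The two compounds differ only in the length of the saturated chain on a nitrogen on an aromatic ring. Shortening that chain gives a 2.5-fold lower number from compound 1 to compound 2 (0.40 log units; beyond the scatter), a modest step and the only one measured so far.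

Compound 3 `Cc1ccc(-c2cnc(N(Cc3ccc(C(=O)NO)cc3)C(C)C)s2)cc1` changes the same place: isopropyl in place of hexyl on a nitrogen on an aromatic ring. In words, this is isopropyl in place of hexyl on a nitrogen on an aromatic ring. The measured step bears on this change only in part. Isopropyl is branched, and no branched chain has been measured here. Two compounds can suggest a direction but cannot establish a rule. If the direction seen in compound 2 with 5270 nM holds, a further modest drop is expected in this assay, though little change or even a rise remains possible. For compound 3 the expected value is 2500 nM, with an estimated range of 800 nM to 7000 nM. That would be an expected 2.1-fold lower number from compound 2 to compound 3 (0.32 log units; beyond the scatter).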

Compound 3, concentration for 50% growth inhibition: 1150 nM
Compound 3: the middle estimate sits 2.2-fold (0.34 log units) above what was measured; the measured number falls inside the stated range.
By their numbers in this assay, from the lowest: compound 3; then compound 2; then compound 1.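

In this assay, the change to isopropyl extends the trend seen with the straight chains, giving a 4.6-fold lower number from compound 2 to compound 3 (0.66 log units; beyond the scatter) for the replacement of hexyl at this nitrogen on an aromatic ring. Measured against the longest chain, isopropyl in place of octyl gives a 12-fold lower number from compound 1 to compound 3 (1.06 log units; beyond the scatter) and is the first large step at this position, so among these three compounds the number falls as the group on the nitrogen gets smaller, with none going against that order, and compound 3 is the strongest inhibitor of growth of the three. Nothing available explains why this position responds in this way.

Because isopropyl is both shorter than hexyl and branched, these compounds cannot show whether the lower number of compound 3 comes from its smaller size, its branching, or both, and a straight propyl chain would help to separate those two readings. Going by these compounds, it also remains open whether the trend continues with a still smaller group such as methyl, and how a ring such as cyclopropyl or a chain carrying an amine would behave here.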